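Swapping a saturated ring for an aromatic one in compound 1

The source may hold more compounds than are shown below. What is called first, only, known or untested is meant among the compounds shown, and "the series" means these compounds.

Compounds measured so far:
compound 1 `C[C@@H]1CCCN1c1c(C#N)c2c(N)ncnc2n1C`, 0.4 nM
compound 2 `C[C@@H]1CCCN1c1[nH]c2ncnc(N)c2c1C#N`, 4 nM
compound 3 `C[C@@H]1CCCN1c1c(C#N)c2c(N)nc(Nc3cnn(C)c3)nc2n1C`, 0.1 nM

These three compounds were tested in an assay on isolated protein for binding affinity to Leucine-rich repeat serine/threonine-protein kinase 2 (Homo sapiens), read by TR-FRET and LanthaScreen, with a stated time of 2 h; a higher number here means a weaker inhibitor, a lower number a stronger inhibitor. Compound 1 `C[C@@H]1CCCN1c1c(C#N)c2c(N)ncnc2n1C` gives 0.4 nM, the second strongest of the three. Its nearest neighbour is compound 3 `C[C@@H]1CCCN1c1c(C#N)c2c(N)nc(Nc3cnn(C)c3)nc2n1C`, which gives 0.1 nM; the step of a 4.0-fold lower number from compound 1 to compound 3 (0.60 log units; beyond the scatter) comes from adding a (1-methyl-1H-pyrazol-4-yl)amino group to the shared core. Its furthest neighbour is compound 2 `C[C@@H]1CCCN1c1[nH]c2ncnc(N)c2c1C#N`, which gives 4 nM; the step of a 10-fold higher number from compound 1 to compound 2 (1.00 log units; beyond the scatter) comes from removing the methyl on the aromatic nitrogen.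

Compound 4 `Cn1c(-n2cccc2)c(C#N)c2c(N)ncnc21` has not yet been measured. It differs from compound 1 in one place: 1H-pyrrol-1-yl in place of 2-methylpyrrolidin-1-yl on an aromatic carbon. Neither measured step touches this part of the structure, so there is no direct guide to its effect; the two known steps only show that single changes to the core can move the number modestly in either direction. The change replaces a saturated ring that carries a methyl and a stereocentre with an aromatic ring, and the expectation is a modest loss in this assay, a 10-fold higher number from compound 1 to compound 4 (1.00 log units; beyond the scatter), giving an estimated 4 nM with a range from 0.8 nM to 30 nM.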

Compound 4, inhibition constant: 239 nM
Compound 4: the middle estimate sits 60-fold (1.78 log units) below what was measured; the measured number lies above the stated range.
By their numbers in this assay, from the lowest: compound 3; then compound 1; then compound 2; then compound 4.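

In this assay, among these compounds, this position turns out to be far more sensitive than the earlier compounds could show: 1H-pyrrol-1-yl in place of 2-methylpyrrolidin-1-yl gives a 600-fold higher number from compound 1 to compound 4 (2.78 log units; beyond the scatter) and counts as a large step, whereas both earlier single changes were modest and were made elsewhere on the shared core. The swap keeps a five-membered ring with one nitrogen and leaves the counted hydrogen-bond donors and acceptors unchanged, so those counts do not separate compound 1 from compound 4. What does change is that the ring becomes aromatic, while the methyl and the defined stereocentre are lost, and no measurement shown here says why affinity falls so steeply with this swap.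

Still open, on these data alone, is which of these differences carries the loss: an unsubstituted pyrrolidin-1-yl group would keep the saturated ring while dropping the methyl and the stereocentre, and so would begin to pull them apart. Also open, as far as these compounds go, is how much room this position allows for other groups, such as a larger piperidin-1-yl ring or an open-chain dimethylamino group.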